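This account rests on a few compounds, and the source may have more. Where it says the series, first, only, none or still open, it means among the compounds named here.

Of the compounds shown here, three sharing one core have been tested in a functional assay on the whole organism for inhibition, with Rattus norvegicus as the target, read by paw edema, with a stated time of 30 min, at a dose of 20 mg/kg by the oral route; on this read-out higher numbers stand for a stronger effect at the one dose given and lower numbers for a weaker effect. Compound 1 `COc1ccc(OCC2=NCCO2)cc1` gives 16.6%, compound 2 `Clc1ccc(OCC2=NCCO2)cc1` gives 30.3%, and compound 3 `Brc1ccc(OCC2=NCCO2)cc1` gives 35.5%. Compound 3 stands highest of the three numbers, though its gap to compound 2 is within the scatter, while its gap to compound 1 is beyond it. The measured steps show a number 13.7 percentage points higher from compound 1 to compound 2 (beyond the scatter) and a number 18.9 percentage points higher from compound 1 to compound 3 (beyond the scatter), both modest, and a number 5.2 percentage points higher from compound 2 to compound 3 (within the scatter).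

Compound 4 `O=[N+]([O-])c1ccc(OCC2=NCCO2)cc1` has not yet been measured in this assay. It differs from compound 3 in one place: nitro in place of bromo on an aromatic carbon. For the measured compounds named here, no measured step involves a nitro group, so the steps that bear on this change are only indirect: swapping methoxy for chloro or bromo raised the number modestly, and swapping chloro for bromo changed nothing beyond the scatter. On that basis the expectation for compound 4 is a small step in this assay, a number 5.5 percentage points lower from compound 3 to compound 4 (within the scatter), which may well stay within the scatter. Compound 4 is estimated at 30%, within a range from 12% to 48%.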

Compound 4, a percentage reported as inhibition, in the whole organism at one dose (the size of the read-out at that dose, not a potency): 29.2%
For compound 4 the middle estimate is 0.8 percentage points above the measured one; measured number inside the range.
By their numbers in this assay, from the lowest: compound 1; then compounds 4, 2 and 3 (each within the scatter of the next).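

In this assay, a nitro group, with its three heavy atoms and two hydrogen-bond acceptors, can stand on this aromatic carbon in place of a single halogen atom without a shift beyond the scatter: the data show a number 6.3 percentage points lower from compound 3 to compound 4 (within the scatter) and a number 1.1 percentage points lower from compound 2 to compound 4 (within the scatter). Set against methoxy, the nitro group gives a clearer difference, a number 12.6 percentage points higher from compound 1 to compound 4 (beyond the scatter), so compound 1 now stands apart from all three other compounds, and not only from the two halogen compounds. Nothing measured here explains why these groups give such values.

An amine, a carboxylic acid or a longer chain at this position could still give a quite different number. Each value is also a read-out at one dose, so how the potencies of these compounds compare remains open.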